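The source may report more compounds than this note shows. Statements on the series, on what has been measured and on what is new or still open speak of the compounds shown alone.

Working notes on the series. In a functional assay on HCT-116 cells (Homo sapiens) for inhibition, read by MTT assay, with a stated time of 72 h (on this read-out lower numbers stand for stronger inhibition of growth and higher numbers for weaker inhibition of growth), compound 1 (`NNC(=O)COc1ccncc1-c1ccc2ccccc2c1`) has "not determined" (no result reported) as its entry and compound 2 (`O=C(O)COc1ccncc1-c1ccc2ccccc2c1`) has "not determined" (no result reported) as its entry. Among the measured compounds shown here, compound 3 (`CCOC(=O)/C=C/c1ccncc1-c1ccc2ccccc2c1`) gives 910 nM as the only number so far, so it cannot yet be ranked against the others. Compound 4 (`CNC(=O)CCc1ccncc1-c1ccc2ccccc2c1`) carries 2-(methylcarbamoyl)ethyl in place of 2-(ethoxycarbonyl)ethenyl on an aromatic carbon. For the measured compounds named here, no measured step calibrates this exchange, and compound 3 at 910 nM is the sole anchor. The expected move is a 2.2-fold higher number from compound 3 to compound 4 (0.34 log units; beyond the scatter) toward weaker inhibition of growth, modest in size, and a result within the scatter remains possible. Compound 4 is expected to read 2000 nM (estimated range 500 nM to 8000 nM).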

Compound 4, concentration for 50% growth inhibition: 19300 nM
Beside the measured number, compound 4's estimate is 9.7-fold (0.98 log units) below it, and the stated range ends below it.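

In this assay the position opposite the ring nitrogen proves sensitive to its substituent: 2-(methylcarbamoyl)ethyl in place of 2-(ethoxycarbonyl)ethenyl gives a 21-fold higher number from compound 3 to compound 4 (1.33 log units; beyond the scatter) toward weaker inhibition of growth. This first measured step shows that the group at this position can move the read-out by a large amount. Nothing available explains the size of this step. From the compounds shown here alone, the exchange alters both the chain and its terminal group, so their separate contributions remain open. Also open, going by these compounds, is how a carboxylic acid or an amine at this position would read.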